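The source may hold more compounds than are shown below. What is called first, only, known or untested is meant among the compounds shown, and "the series" means these compounds.

Measured compounds:
Compound 1 `O=C(/C=C/c1ccc2c(c1)B(O)OC2)c1ccc(F)cc1`: 2800 nM
Compound 2 `O=C(/C=C/c1ccc2c(c1)B(O)OC2)c1ccc(Cl)cc1`: 9300 nM
Compound 3 `O=C(/C=C/c1ccc2c(c1)B(O)OC2)c1ccc(O)cc1`: 24100 nM

In a functional assay on HCT-116 cells (Homo sapiens) for cytotoxicity, read by MTT assay, with a stated time of 48 h (a higher number here means a weaker inhibitor, a lower number a stronger inhibitor), compound 1 gives the lowest number of the three; the nearest step away from it is a 3.3-fold higher number from compound 1 to compound 2 (0.52 log units; beyond the scatter), the furthest is an 8.6-fold higher number from compound 1 to compound 3 (0.93 log units; beyond the scatter).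

Compound 4 `Nc1ccc(C(=O)/C=C/c2ccc3c(c2)B(O)OC3)cc1` has not yet been measured. It differs from compound 1 in one place: amino in place of fluoro on an aromatic carbon. Amino, like hydroxy, brings one hydrogen-bond donor and one acceptor, so the step of an 8.6-fold higher number from compound 1 to compound 3 (0.93 log units; beyond the scatter) is the closest guide, while a 3.3-fold higher number from compound 1 to compound 2 (0.52 log units; beyond the scatter) shows that even a chloro in place of fluoro raised the number. Both known replacements of the fluoro raised the number beyond the scatter, and a modest rise is expected here too, a 6.4-fold higher number from compound 1 to compound 4 (0.81 log units; beyond the scatter). For compound 4 the estimate is 18000 nM, with a range from 6000 nM to 55000 nM.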

Compound 4, half-maximal inhibitory concentration: 26100 nM
Beside the measured number, compound 4's estimate is 1.5-fold (0.16 log units) below it; the range from low to high includes it.
By their numbers in this assay, from the lowest: compound 1; then compound 2; then compounds 3 and 4 (each within the scatter of the next).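

In this assay, amino behaves like hydroxy at this position: the change from fluoro is large (a 9.3-fold higher number from compound 1 to compound 4 (0.97 log units; beyond the scatter)), yet swapping hydroxy for amino leaves the number unchanged (a 1.1-fold higher number from compound 3 to compound 4 (0.03 log units; within the scatter)). Amino also stands apart from chloro (a 2.8-fold higher number from compound 2 to compound 4 (0.45 log units; beyond the scatter)), so among these four groups, fluoro alone gives the lowest number. Nothing available explains these differences.

Where a bromo, a methyl or a methoxy in the same place would fall remains open. So does whether an acetylated amino would behave like the free amino.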